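Imidazolyl for Carbamoylphenyl at the Sulfur-Linked Carbon

This account rests on a few compounds, and the source may have more. Where it says the series, first, only, none or still open, it means among the compounds named here.

compound 1 `N#Cc1c(N)nc(SCc2cccc(C(N)=O)c2)c(C#N)c1-c1ccc(OCC2CC2)cc1`: 1%
compound 2 `C=CCOc1ccc(-c2c(C#N)c(N)nc(SCc3ccn[nH]3)c2C#N)cc1`: 13%

In an assay on CHO cells for displacement of a labelled ligand from adenosine receptor A3 (Homo sapiens), read by scintillation counting, with a stated time of 120 min, tested at 1 uM (on this read-out higher numbers stand for more inhibition at the one concentration tested (going by the name of the read-out) and lower numbers for less inhibition), compound 1 gives 1% and compound 2 gives 13%. Compound 1 stands lowest of the two numbers; compound 2 lies higher by a gap beyond the scatter. Compound 3 `N#Cc1c(N)nc(SCc2cnc[nH]2)c(C#N)c1-c1ccc(OCC2CC2)cc1` is not yet measured. Its difference from compound 1: 1H-imidazol-5-yl in place of 3-carbamoylphenyl on a saturated chain carbon bound to a sulfur. Compound 2, which also bears a small five-membered aromatic ring with two nitrogens, reads higher than compound 1, so a rise is plausible. The step of a number 9 percentage points higher from compound 1 to compound 3 (within the scatter) is expected to be a modest increase, beyond the scatter. Compound 3 is estimated at 10%, with a range from 0% to 25%.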

Compound 3, a percentage reported as inhibition, at one concentration (the size of the read-out at that concentration, not a potency): 1%
Compound 3: middle estimate off by 9 percentage points, on the high side; the measured number falls inside the stated range.
By their numbers in this assay, from the lowest: compounds 1 and 3 (each within the scatter of the next); then compound 2.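

In this assay, 1H-imidazol-5-yl in place of 3-carbamoylphenyl on a saturated chain carbon bound to a sulfur gives no change at the digits printed from compound 1 to compound 3 (within the scatter). At this position, a five-membered aromatic ring with 2 hetero atoms and 5 heavy atoms therefore reads the same as a six-membered aromatic ring of carbon only, carrying 9 heavy atoms with the carbamoyl group. As far as these compounds go, whether a carboxylic acid in place of the carbamoyl group, or an amine on a longer chain at this carbon, would separate from these two remains open. No measurement in hand bears on why this pair reads alike.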